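Swapping a Cyanophenyl Group for a Trimethoxyphenyl Group

The source may hold more compounds than are shown below. What is called first, only, known or untested is meant among the compounds shown, and "the series" means these compounds.

This small set of compounds shares one core and differs mainly in the group carried at the end of a double-bonded chain. They were examined in a functional assay on HeLa cells (Homo sapiens) for cytotoxicity, read by MTT assay, with a stated time of 72 h; a lower number here means a stronger inhibitor, a higher number a weaker inhibitor. There, compound 1 (`COc1cc2ncnc(Nc3ccc(F)c(Cl)c3)c2cc1NC(=O)/C=C/c1ccc(F)cc1Cl`) stands as "not determined" (no result reported), so it offers no number to compare.

Within the data shown here, compound 2 (`COc1ccc(/C=C/C(=O)Nc2cc3c(Nc4ccc(F)c(Cl)c4)ncnc3cc2O[C@H]2CCOC2)c(OC)c1`) gives 26500 nM, the only actual number in the set.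

Compound 3 (`N#Cc1ccc(/C=C/C(=O)Nc2cc3c(Nc4ccc(F)c(Cl)c4)ncnc3cc2O[C@H]2CCOC2)cc1`) is the starting point here, yet compound 3 also stands as "not determined" (no result reported). Its place on the scale is therefore unknown, and it cannot be ranked against compound 2.

The next compound, compound 4 (`COc1ccc(/C=C/C(=O)Nc2cc3c(Nc4ccc(F)c(Cl)c4)ncnc3cc2O[C@H]2CCOC2)c(OC)c1OC`), has not yet been measured. The structural change is 2,3,4-trimethoxyphenyl in place of 4-cyanophenyl on a double-bonded chain carbon bound to a double-bonded chain carbon.

With no number for compound 3, the size of this step cannot be judged from its starting point. Among the measured compounds shown here, the only available anchor is compound 2 at 26500 nM, so no shift beyond the usual scatter from that value is expected in this assay, and no direction can be favoured with confidence.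

For compound 4 the expected value is 20000 nM, with an estimated range from 6000 nM to 50000 nM.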

Compound 4, half-maximal inhibitory concentration: 4830 nM
For compound 4 the middle estimate is 4.1-fold (0.62 log units) above the measured one; the measured number lies below the stated range.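

In this assay, putting one methoxy in place of hydrogen on an aromatic carbon of the end group gives a 5.5-fold lower number from compound 2 to compound 4 (0.74 log units; beyond the scatter). Among these compounds, this is the first measured comparison in the set, and it shows that the aromatic ring on the double-bonded chain is a place where a single small edit can move the number beyond the usual scatter, here towards stronger inhibition. The data offer nothing that explains this shift.

As far as these compounds go, the swap of 4-cyanophenyl for 2,3,4-trimethoxyphenyl itself cannot be read, as compound 3 has no reported result, so the standing of the nitrile-bearing ring against the methoxy-bearing rings remains unknown. From the compounds shown here alone, a single pair also sets no trend, so it remains open whether a hydroxyl or an ethoxy in place of one of the methoxy groups of compound 4, or a dimethylamino group on the same ring, would lower the number further or raise it again.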